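A few compounds are considered here, and "the series" means these few. Any claim that something is new, unique, unknown or untested is made for them only; others in the source may bear on it.

Compound 1, `O=C1CS/C(=N/Nc2nncc3ccccc23)N1c1ccccc1`, is the starting point of this step. Within the data shown here, in a functional assay on MCF7 cells (Homo sapiens) for antiproliferative activity, read by sulforhodamine B assay, with a stated time of 72 h (a lower number here means a stronger inhibitor, a higher number a weaker inhibitor), compound 1 gives 77 nM, the highest of the three numbers measured so far. Its closest neighbour is compound 3, `O=S(=O)(Nc1nccs1)c1ccc(Nc2nncc3ccccc23)cc1`, which in this assay gives 55 nM, a gap that lies within the scatter of repeated measurements, so the two cannot be ranked against each other. The furthest is compound 2, `C(=C/c1ccccc1)\C(=N\Nc1nncc2ccccc12)c1ccccc1`, which in this assay gives 2.2 nM, a gap well beyond the scatter.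

The compound still to be measured is compound 4, `CCN1C(=O)CS/C1=N/Nc1nncc2ccccc12`. It differs from compound 1 in one place: ethyl in place of phenyl on an amide-type nitrogen in a ring. Among the measured compounds shown here, no step between two already measured compounds resembles this change, so nothing within the set indicates its likely size. The removal of a six-membered aromatic ring in favour of a two-carbon chain at this position is expected to cost some potency, though only moderately. The expected step from compound 1 to compound 4 in this assay is a 2.6-fold higher number from compound 1 to compound 4 (0.41 log units; beyond the scatter), a weakening that is estimated to exceed the scatter only slightly. For compound 4 the estimated value in this assay is 200 nM, with a range from 60 nM to 700 nM.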

Compound 4, half-maximal inhibitory concentration: 98 nM
Beside the measured number, compound 4's estimate is 2.0-fold (0.31 log units) above it; the measured number falls inside the stated range.
By their numbers in this assay, from the lowest: compound 2; then compounds 3, 1 and 4 (each within the scatter of the next).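

In this assay, ethyl in place of phenyl on the amide-type nitrogen in a ring gives a 1.3-fold higher number from compound 1 to compound 4 (0.10 log units; within the scatter), so compound 1 and compound 4 cannot be told apart. Among these compounds, this is the first step read at this position, and it shows that, for these two compounds, the six-membered aromatic ring can give way to a two-carbon chain while the number stays within the scatter. Nothing available accounts for this result.

From the compounds shown here alone, it remains open whether this tolerance extends to other groups on the same nitrogen, such as methyl, a longer chain like butyl, or a chain ending in an amine or a carboxylic acid. The compounds shown also leave open whether a phenyl carrying a fluorine or a methoxy group would give a different number from the unsubstituted phenyl.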